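A few compounds are considered here, and "the series" means these few. Any claim that something is new, unique, unknown or untested is made for them only; others in the source may bear on it.

Cancer cell growth can be slowed by small molecules, and one way to compare such molecules is to find the concentration they need to slow that growth. In a functional assay on HL-60 cells (Homo sapiens) for antiproliferative activity, read by MTT assay, with a stated time of 72 h (a higher number here means a weaker inhibitor, a lower number a stronger inhibitor), compound 3 `N=C(NS(=O)(=O)c1ccccc1Cl)N1CCN(c2cc3c(cc2F)c(=O)c(C(=O)O)cn3C2CC2)CC1` gives 43 nM. This puts it level with compound 1 `N=C(NS(=O)(=O)c1ccccc1)N1CCN(c2cc3c(cc2F)c(=O)c(C(=O)O)cn3C2CC2)CC1` at 43 nM and with compound 2 `CCn1cc(C(=O)O)c(=O)c2cc(F)c(N3CCN(C(=N)NS(=O)(=O)c4cccc(Cl)c4)CC3)cc21` at 43 nM.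

The next molecule, compound 4 `N=C(NS(=O)(=O)c1cccc(Cl)c1)N1CCN(c2cc3c(cc2F)c(=O)c(C(=O)O)cn3C2CC2)CC1`, has not yet been measured. It has 3-chlorophenyl in place of 2-chlorophenyl on a sulfonyl sulfur. The atoms stay the same and only their connection changes.

For the measured compounds named here, no measured pair shows this exact change. The closest evidence is the swap of chloro for hydrogen on an aromatic carbon, which gave no change at the digits printed from compound 1 to compound 3 (within the scatter). If adding the chlorine made no visible difference, moving it may well do little too. Going by the values given here, compound 2, which also carries 3-chlorophenyl on a sulfonyl sulfur, gives 43 nM, and this fits that view, although it is only one value.

The expected step is no change at the digits printed from compound 3 to compound 4 (within the scatter), so no shift beyond the scatter is anticipated in either direction. For compound 4 the estimated value is 43 nM, with an expected range from 22 nM to 85 nM.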

Compound 4, half-maximal inhibitory concentration: 43 nM
Beside the measured number, compound 4's estimate shows no gap at the digits printed; measured number inside the range.
By their numbers in this assay, from the lowest: compounds 1, 2, 3 and 4 (each within the scatter of the next).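

In this assay, for the compounds shown here, moving the chlorine gives no change at the digits printed from compound 3 to compound 4 (within the scatter) and so shows what no earlier pair could: on this sulfonyl sulfur, with the shared core held fixed, 3-chlorophenyl and 2-chlorophenyl cannot be told apart. The 3-chlorophenyl group can now also be read against plain phenyl, where chloro in place of hydrogen gives no change at the digits printed from compound 1 to compound 4 (within the scatter) and matches the earlier no change at the digits printed from compound 1 to compound 3 (within the scatter) for 2-chlorophenyl, so neither chlorine placement separates from the unsubstituted ring in these compounds. Going by these compounds alone, with 3-chlorophenyl held constant, cyclopropyl in place of ethyl on an aromatic nitrogen gives no change at the digits printed from compound 2 to compound 4 (within the scatter) and offers the first clean reading of a change away from the sulfonyl side of the molecule.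

The compounds shown leave open whether this flat picture would survive a different kind of group in place of the chloro, such as methoxy, an amine or a carboxylic acid. The data on hand offer no information on why these changes leave the number where it stands.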